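From ethyl to cyano on one aromatic carbon

A few compounds are considered here, and "the series" means these few. Any claim that something is new, unique, unknown or untested is made for them only; others in the source may bear on it.

In a functional assay (Nicotiana tabacum) (on this read-out higher numbers stand for weaker inhibition and lower numbers for stronger inhibition), compound 1 `CSc1nc(Nc2ccc(Br)cc2)c2cccnc2n1` gives 5750 nM and compound 2 `CCc1ccc(Nc2nc(SC)nc3ncccc23)cc1` gives 7150 nM on the same read-out. For the measured compounds named here, compound 2 therefore stands level with compound 1, the only other compound measured so far. Going by the values given here, compound 3 `CSc1nc(Nc2ccc(C#N)cc2)c2cccnc2n1` has no measurement yet. It differs from compound 2 by cyano in place of ethyl on an aromatic carbon and carries cyano in place of ethyl on an aromatic carbon, para to a large group. Among the compounds with values here, one measured step bears on this position, a 1.2-fold higher number from compound 1 to compound 2 (0.09 log units; within the scatter) and it brought ethyl in place of bromo. That step is small, but it says nothing directly about cyano, so the uncertainty stays wide. No step beyond the scatter is expected in this assay from this change. The estimated step is a 1.1-fold lower number from compound 2 to compound 3 (0.04 log units; within the scatter) and it has no clear direction. Compound 3 is expected at 6500 nM with an estimated range from 2500 nM to 16000 nM in repeated measurements.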

Compound 3, half-maximal inhibitory concentration: 7560 nM
The estimate for compound 3 lay 1.2-fold (0.07 log units) below the measured number; the measured number falls inside the stated range.
By their numbers in this assay, from the lowest: compounds 1, 2 and 3 (each within the scatter of the next).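

In this assay, cyano proves no different from ethyl at this position, para to a large group (a 1.1-fold higher number from compound 2 to compound 3 (0.02 log units; within the scatter)). The comparison with bromo gives the same picture (a 1.3-fold higher number from compound 1 to compound 3 (0.12 log units; within the scatter)), so all three groups now tested here lie within the scatter of one another, even though cyano adds a hydrogen-bond acceptor and a triple bond that ethyl lacks. No independent data accompany these numbers to explain why the three compounds stay level.

From the compounds shown here alone, whether an amine, a carboxylic acid or a longer chain on this aromatic carbon would shift the number beyond the scatter remains open. Compounds 1, 2 and 3 also share the rest of their structure, so they cannot tell whether a change elsewhere on the shared core would matter more.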